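The source may hold more compounds than are shown below. What is called first, only, known or untested is meant among the compounds shown, and "the series" means these compounds.

Measured compounds in a functional assay on CHO cells with adenosine receptor A1 (Homo sapiens) as the target, read by cAMP accumulation and immunoassay, with a stated time of 6 min, tested at 0.01 uM; on this read-out lower numbers stand for a stronger effect and higher numbers for a weaker effect at the one concentration tested:

Compound 1 `Nc1scc(CN2CCN(c3ccc(Cl)cc3Cl)CC2)c1C(=O)c1ccc(Cl)cc1` gives 2%.
Compound 2 `Nc1scc(CN2CCN(c3cccc(Cl)c3Cl)CC2)c1C(=O)c1ccc(Cl)cc1` gives 1%.
Compound 3 `Nc1scc(CN2CCN(c3ccc(F)cc3Cl)CC2)c1C(=O)c1ccc(Cl)cc1` gives 6.1%.

Among these three numbers compound 3 shows the highest value, but its nearest neighbour is compound 1, with a number 4.1 percentage points higher from compound 1 to compound 3 (within the scatter), and its furthest is compound 2, with a number 5.1 percentage points higher from compound 2 to compound 3 (within the scatter); both gaps sit within the scatter, so the three compounds cannot be told apart on this read-out.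

The next compound, compound 4 `Nc1scc(CN2CCN(c3ccc(OC(F)(F)F)cc3)CC2)c1C(=O)c1ccc(Cl)cc1`, differs from compound 3 in one place: 4-(trifluoromethoxy)phenyl in place of 2-chloro-4-fluorophenyl on an amine nitrogen in a ring. Going by the values given here, the steps that bear on this change are those that exchanged the aryl group on the same ring nitrogen, namely a number 1 percentage points lower from compound 1 to compound 2 (within the scatter) and a number 5.1 percentage points higher from compound 2 to compound 3 (within the scatter), and neither moved the number beyond the scatter. Compound 4 is therefore expected to give a number close to the three measured ones, with a number 1.9 percentage points higher from compound 3 to compound 4 (within the scatter) as the expected step. For compound 4 the estimate is 8%, with a range from 0% to 25%.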

Compound 4, a percentage reported as activity, at one concentration (the size of the read-out at that concentration, not a potency): 0%
The estimate for compound 4 lay 8 percentage points above the measured number; low and high end bracket the measured number.
By their numbers in this assay, from the lowest: compounds 4, 2, 1 and 3 (each within the scatter of the next).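

In this assay, going by these compounds alone, the ring nitrogen carries, for the first time, a phenyl group without chlorine, and the change to 4-(trifluoromethoxy)phenyl gives a number 6.1 percentage points lower from compound 3 to compound 4 (within the scatter) and so does not separate compound 4 from compound 3. The same holds for the other two exchanges on this nitrogen, which give a number 1 percentage points lower from compound 2 to compound 4 (within the scatter) and a number 2 percentage points lower from compound 1 to compound 4 (within the scatter) and show that chlorine on the phenyl group is not needed for a number in this range among these four compounds. No measurement at hand accounts for this result.

Because all four numbers lie within the scatter at the one concentration tested, any difference among these compounds remains unresolved. From the compounds shown here alone, it also remains open whether a carboxylic acid or an amine on the phenyl group, or a cyclohexyl group in place of the phenyl group, would leave the number in this range.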